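The source may hold more compounds than are shown below. What is called first, only, known or untested is meant among the compounds shown, and "the series" means these compounds.

Measured in a functional assay on SEM cells (Homo sapiens) for cytotoxicity, with a stated time of 72 h; a lower number here means that less compound is needed, a higher number that more compound is needed for the effect:
Compound 1 `C=C[C@@](C)(/C=C/c1ccc(O)c(/C=C/C(=O)c2ccccc2)c1)CCC=C(C)C`: 8000 nM
Compound 2 `C=C[C@@](C)(/C=C/c1ccc(O)c(/C=C/C(=O)O)c1)CCC=C(C)C`: > 36600 nM

For the measured compounds named here, compound 1 holds the only true number, 8000 nM. Compound 2 reaches only a limit of the assay, > 36600 nM. Compound 3 `COc1ccc(/C=C/[C@@](C)(/C=C/c2ccc(O)c(/C=C/C(=O)c3ccccc3)c2)CCC=C(C)C)cc1` carries 2-(4-methoxyphenyl)ethenyl in place of vinyl (2-(4-methoxyphenyl)ethenyl in place of vinyl on a saturated chain carbon bound to a double-bonded chain carbon and two saturated chain carbons). Going by the values given here, no measured step covers this place. The nearest guide is an at least 4.5-fold higher number from compound 1 to compound 2 (0.66 log units; beyond the scatter), where hydroxy replaces phenyl elsewhere, and there losing an aromatic ring came with a higher number. Gaining one in this assay is therefore weakly expected to lower the number, by an estimated 2.3-fold lower number from compound 1 to compound 3 (0.36 log units; beyond the scatter), perhaps not beyond the scatter. Compound 3 is estimated at 3500 nM, with an expected range of 900 nM to 16000 nM.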

Compound 3, half-maximal effective concentration: 36600 nM
Compound 3: middle estimate off by 10-fold (1.02 log units), on the low side; the whole stated range lies below it.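

In this assay, putting 2-(4-methoxyphenyl)ethenyl in place of vinyl gives a 4.6-fold higher number from compound 1 to compound 3 (0.66 log units; beyond the scatter) and so more compound is needed for the effect. Gaining an aromatic ring at this saturated chain carbon therefore does not lower the number, so the trend from the carbonyl carbon, where losing phenyl raised it, does not carry over to this place. The new value also stands at the same figure as the limit seen in this set: the limit of > 36600 nM in this assay, at which 1 of the 3 values shown sits.

Only vinyl and 2-(4-methoxyphenyl)ethenyl are shown here, so the role of the methoxy group cannot be separated from that of the ring. As far as these compounds go, whether a methyl or an aminomethyl group at this carbon would lower the number remains open.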